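This account rests on a few compounds, and the source may have more. Where it says the series, first, only, none or still open, it means among the compounds named here.

Working notes on the series.

Compound 1 `COCC1(COC)Oc2ccc(Br)cc2[C@@H](Nc2ccc(=O)n(C)n2)[C@@H]1O` and compound 2 `COCC1(COC)Oc2ccc([N+](=O)[O-])cc2[C@@H](Nc2ccc(=O)n(C)n2)[C@@H]1O` share a core and differ in one place, (nitro in place of bromo on an aromatic carbon). In an ADME assay on the whole organism (blood) for pharmacokinetics, with Canis familiaris (Canis lupus familiaris) as the target (a lower number here means that the compound disappears faster, a higher number that the compound lasts longer), compound 1 gives 0.0583 h, while compound 2 gives 0.167 h, so that the change made a 2.9-fold higher number from compound 1 to compound 2 (0.46 log units; beyond the scatter).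

Compound 3 `COCC1(COC)Oc2ccc(Br)cc2[C@@H](N=C(NC#N)c2cccnc2)[C@@H]1O` carries a different substituent on the same scaffold; the difference between the core of compound 3 and the core of compound 1 is not broken down here. In this assay compound 3 gives 0.0167 h, the lowest of the three numbers recorded so far.

Compound 4 `COCC1(COC)Oc2ccc([N+](=O)[O-])cc2[C@@H](N=C(NC#N)c2cccnc2)[C@@H]1O` is not yet measured. It differs from compound 3 by nitro in place of bromo on an aromatic carbon, which is the same kind of change as that from compound 1 to compound 2. Because the earlier pair moved by a 2.9-fold higher number from compound 1 to compound 2 (0.46 log units; beyond the scatter), a step of similar size, a 2.9-fold higher number from compound 3 to compound 4 (0.46 log units; beyond the scatter), is expected here, resting on that one pair alone. On that basis compound 4 is estimated at 0.048 h in this assay, with a plausible range of 0.02 h to 0.12 h.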

Compound 4, half-life: 0.0167 h
The estimate for compound 4 lay 2.9-fold (0.46 log units) above the measured number; measured number outside the range, below it.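

In this assay, nitro in place of bromo on an aromatic carbon gives no change at the digits printed from compound 3 to compound 4 (within the scatter), so the step seen on the core of compound 1 does not reappear on the core of compound 3. The size of this change therefore depends on the core within these two pairs, and a step read on one core is not a safe guide to the other: the same change on two cores in this assay, a 2.9-fold higher number (0.46 log units; beyond the scatter) from compound 1 to compound 2 and no change at the digits printed (within the scatter) from compound 3 to compound 4, 2.9-fold (0.46 log units) apart, beyond the scatter of two such steps. For the compounds shown here, this does not show what in the two cores sets the steps apart, and with only two pairs it gives no general rule for the series.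

Going by these compounds, it remains open how a third core would respond to the same change, and whether either pair's behaviour would recur there. On these data alone, it is also open whether a different group on this aromatic carbon, such as an amine or a carboxylic acid, would separate the two cores in the same way as nitro and bromo do.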